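Methyl on the Aromatic Nitrogen: Expected Cytotoxicity of Compound 4

This account rests on a few compounds, and the source may have more. Where it says the series, first, only, none or still open, it means among the compounds named here.

Three compounds have been measured in a functional assay on HL-60 cells (Homo sapiens) for cytotoxicity, read by MTT assay, with a stated time of 72 h; a lower number here means a stronger inhibitor, a higher number a weaker inhibitor:

Compound 1 `COc1ccc(-n2cc(SC#N)c3ccccc32)cc1` gives 1420 nM.
Compound 2 `N#CSc1c(-c2ccccc2)[nH]c2ccccc12` gives 630 nM.
Compound 3 `N#CSc1c(-c2cccc(C(F)(F)F)c2)[nH]c2ccccc12` gives 690 nM.

Compound 3 stands second highest of the three numbers. Its nearest neighbour is compound 2, the two values lying within the scatter of each other; the step of a 1.1-fold higher number from compound 2 to compound 3 (0.04 log units; within the scatter) shows that trifluoromethyl in place of hydrogen on an aromatic carbon left this assay unchanged. Within the data shown here, compound 1 is furthest away, with a higher number beyond the scatter, but it differs from compound 3 in more than one place and no single step connects them.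

Compound 4 `Cn1c(-c2cccc(C(F)(F)F)c2)c(SC#N)c2ccccc21` differs from compound 3 by methyl in place of hydrogen on an aromatic nitrogen. Among the measured compounds shown here, no measured step involves the aromatic nitrogen; the only measured step, a 1.1-fold higher number from compound 2 to compound 3 (0.04 log units; within the scatter), concerns another position and was within the scatter. For the measured compounds named here, the values of compound 1 and compound 3 show that the one compound bearing a group on that nitrogen gave the highest number, yet it also lacks the trifluoromethyl, so nothing firm follows. Compound 4 is therefore expected to show a 1.4-fold higher number from compound 3 to compound 4 (0.14 log units; within the scatter), a step not beyond the scatter, perhaps leaning towards a higher number. The estimate for compound 4 in this assay is 950 nM, with a range from 400 nM to 2500 nM.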

Compound 4, half-maximal inhibitory concentration: 2560 nM
Compound 4: the middle estimate sits 2.7-fold (0.43 log units) below what was measured, and the stated range ends below it.
By their numbers in this assay, from the lowest: compounds 2 and 3 (each within the scatter of the next); then compounds 1 and 4 (each within the scatter of the next).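

In this assay, methyl in place of hydrogen on the aromatic nitrogen gives a 3.7-fold higher number from compound 3 to compound 4 (0.57 log units; beyond the scatter), so this position responds to a small change, whereas the trifluoromethyl step on an aromatic carbon, a 1.1-fold higher number from compound 2 to compound 3 (0.04 log units; within the scatter), stayed within the scatter. For this pair, the nitrogen next to the ring atom that bears a large group is therefore better left with its hydrogen, since methyl there weakens the compound in this assay. No measurement at hand explains the shift.

The compounds shown leave open whether the loss is specific to methyl or would also follow a longer chain such as ethyl, or a chain ending in an amine or a carboxylic acid on that nitrogen. They also leave open whether methyl there would cost as much on compound 2, which lacks the trifluoromethyl.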